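Adding a Methoxy Group to Compound 3

A few compounds are considered here, and "the series" means these few. Any claim that something is new, unique, unknown or untested is made for them only; others in the source may bear on it.

Measured in a functional assay on HepG2 cells (Homo sapiens) for cytotoxicity, read by spectrophotometry, with a stated time of 72 h; a higher number here means a weaker inhibitor, a lower number a stronger inhibitor:
- Compound 1 `COc1ccc(-c2cccc(=O)n2-c2cc(OC)c(OC)c(OC)c2)cc1OCc1ccccc1`: 269 nM
- Compound 2 `COc1ccc(-c2cccc(=O)n2-c2cc(OC)c(OC)c(OC)c2)cc1O`: < 10 nM (a limit)
- Compound 3 `COc1ccc(-c2cccc(=O)n2-c2cc(OC)c(OC)c(OC)c2)cc1`: < 10 nM (a limit)

Compound 3 stands at a limit and not at a number, (the limit of < 10 nM in this assay, at which 2 of the 3 values shown sit). Compound 4 `COc1ccc(-c2cccc(=O)n2-c2cc(OC)c(OC)c(OC)c2)cc1OC` has methoxy in place of hydrogen on an aromatic carbon, ortho to a methoxy group (methoxy in place of hydrogen on an aromatic carbon). The nearest evidence is the large change an at least 26-fold lower number from compound 1 to compound 3 (1.42 log units; beyond the scatter), and the equally large an at least 26-fold lower number from compound 1 to compound 2 (1.42 log units; beyond the scatter), both of which remove the benzyl group. The limits hide any difference in a step that the two limits leave unreadable from compound 2 to compound 3. Methoxy is far smaller than benzyloxy, so little change is expected in this assay, and a limit may again be reported. The expected change is a number no lower from compound 3 to compound 4 (the limit leaves the size open). For compound 4 the estimated value is 10 nM, with an expected range from 3 nM to 50 nM.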

Compound 4, half-maximal inhibitory concentration: 513 nM
For compound 4 the middle estimate is 51-fold (1.71 log units) below the measured one, and the stated range ends below it.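

In this assay this position proves highly sensitive: methoxy in place of hydrogen gives an at least 51-fold higher number from compound 3 to compound 4 (1.71 log units; beyond the scatter), and methyl in place of the hydroxy hydrogen gives an at least 51-fold higher number from compound 2 to compound 4 (1.71 log units; beyond the scatter). Benzyl and methyl on this oxygen cannot be told apart, with a 1.9-fold higher number from compound 1 to compound 4 (0.28 log units; within the scatter), so the earlier large step does not depend on a group as big as benzyloxy. Compound 2 and compound 3 each remain a limit and not a number: the limit of < 10 nM in this assay, at which 2 of the 4 values shown sit.

The compounds shown leave open whether any substituent beyond hydroxy is tolerated on this carbon, such as fluorine or an amine. They also leave open how ethoxy would compare with methoxy and benzyloxy.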